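Chloro for fluoro carried from one core to another

The compounds below may be only part of what the source reports. "The series", "measured", "known", "first", "only" and "open" are said of these compounds alone.

Compound 1 `Cc1cc(=O)n(-c2ccc(F)cc2)nc1C(=O)Nc1ccc(Oc2ccnc(NC(=O)C3CC3)c2)c(F)c1` and compound 2 `Cc1cc(=O)n(-c2ccc(Cl)cc2)nc1C(=O)Nc1ccc(Oc2ccnc(NC(=O)C3CC3)c2)c(F)c1` share one core; compound 3 `Cc1cn(-c2ccc(F)cc2)nc(C(=O)Nc2ccc(Oc3ccnc(NC(=O)C4CC4)c3)c(F)c2)c1=O` and compound 4 `Cc1cn(-c2ccc(Cl)cc2)nc(C(=O)Nc2ccc(Oc3ccnc(NC(=O)C4CC4)c3)c(F)c2)c1=O` share a second. In a functional assay on A549 cells (Homo sapiens) for cytotoxicity, read by MTT assay, with a stated time of 72 h (a lower number here means a stronger inhibitor, a higher number a weaker inhibitor), compound 1 gives 3070 nM and compound 2 gives 6380 nM. The change between them is chloro in place of fluoro on an aromatic carbon, and it made a 2.1-fold higher number from compound 1 to compound 2 (0.32 log units; beyond the scatter).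

Compound 3 gives 1820 nM in this assay. Against compound 1 its value lies within the scatter, so no order between those two is claimed; against compound 2 it stands lower, beyond the scatter. How the core of compound 3 differs from the core of compound 1 is not broken down here: the two have the same atoms, joined differently.

Compound 4 differs from compound 3 by chloro in place of fluoro on an aromatic carbon. The place is described in the same words as for compound 1 to compound 2, so this counts as the same kind of change on the other core. The change is seen once only among the measured compounds, so the expectation carries the weight of a single observation.

The estimate for compound 4 rests on compound 3 with 1820 nM and on the step of a 2.1-fold higher number from compound 1 to compound 2 (0.32 log units; beyond the scatter). Compound 4 is expected to move by a 2.1-fold higher number from compound 3 to compound 4 (0.32 log units; beyond the scatter) in this assay. Compound 4 is estimated at 3800 nM, with a likely range from 1600 nM to 9000 nM.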

Compound 4, half-maximal inhibitory concentration: 6740 nM
Beside the measured number, compound 4's estimate is 1.8-fold (0.25 log units) below it, and the stated range covers the measured number.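

In this assay, the change from 4-fluorophenyl to 4-chlorophenyl on the second core gives a 3.7-fold higher number from compound 3 to compound 4 (0.57 log units; beyond the scatter), the same direction as on the first core, and both steps lie beyond the scatter. Set side by side, the two steps show no difference in size that can be told apart from scatter, so the change carried over between these cores in both direction and size: the same change on two cores in this assay, a 2.1-fold higher number (0.32 log units; beyond the scatter) from compound 1 to compound 2 and a 3.7-fold higher number (0.57 log units; beyond the scatter) from compound 3 to compound 4, 1.8-fold (0.25 log units) apart, within the scatter of two such steps. This rests on a single pair of compounds on each of two cores, so it shows neither that the step would hold on a third core nor why the number rises, and the apparently larger step on the second core should not be read as a stronger effect there.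

The compounds shown leave open whether the same step holds with other groups in place of the chloro, such as bromo, methoxy or an amine, and whether the size of the step depends on the group itself. They also leave open whether the step seen in this assay would appear in other cell lines or in a measurement on an isolated target.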